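A few compounds are considered here, and "the series" means these few. Any claim that something is new, unique, unknown or untested is made for them only; others in the source may bear on it.

Two tetrabromobenzotriazole derivatives carrying a hydroxyalkyl chain on the triazole nitrogen have been examined. Compound 1 `C[C@@H](O)CCn1nc2c(Br)c(Br)c(Br)c(Br)c2n1` bears a hydroxybutyl chain ending in a methyl group, and compound 2 `OC(CCn1nc2c(Br)c(Br)c(Br)c(Br)c2n1)c1ccccc1` carries a phenyl group on the carbon that holds the hydroxyl. In a functional assay on CCRF-CEM cells (Homo sapiens) for antiproliferative activity, read by MTT assay, with a stated time of 24 h, tested at 12.5 uM (a lower number here means a stronger effect, a higher number a weaker effect of the compound at the concentration tested), compound 1 gives 88%, and compound 2 gives 122% in this assay, the higher of the two numbers, standing apart from compound 1 by a margin beyond the scatter of the method.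

Compound 3 `CC(O)CCn1nc2c(Br)c(Br)c(Br)c(Br)c2n1` has not yet been measured. It differs from compound 2 in one place, (methyl in place of phenyl on a saturated chain carbon bound to an oxygen on a saturated carbon and a saturated chain carbon). Because compound 1 gives 88% in this assay, the step of a number 34 percentage points lower from compound 2 to compound 3 (beyond the scatter) is expected to run downward, beyond the scatter. Compound 3 is accordingly estimated at 88% in this assay, within a range from 70% to 106%.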

Compound 3, a percentage reported as activity, at one concentration (the size of the read-out at that concentration, not a potency): 106%
Beside the measured number, compound 3's estimate is 18 percentage points below it, and the stated range covers the measured number.
By their numbers in this assay, from the lowest: compound 1; then compound 3; then compound 2.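

Replacing phenyl with methyl on a saturated chain carbon bound to an oxygen gives a number 16 percentage points lower from compound 2 to compound 3 (beyond the scatter) in this assay, a first single-place step showing that the read-out responds to the group at this position. Identical atoms and bonds do not guarantee the same result either, as the comparison gives a number 18 percentage points higher from compound 1 to compound 3 (beyond the scatter), so how the stereocentre is drawn must be taken into account when reading this series. The structures offer only one difference for that step: the fact that one of compounds 1 and 3 is drawn with a defined configuration and the other without, at the place where they differ

Going by these compounds, it remains open how an amine or a longer chain at this position would read in this assay, and how the S configuration would compare with the R configuration drawn in compound 1. Each number also stands at a single concentration, leaving the response at other concentrations unknown.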